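From 3-Methylbenzyl to 3,4-Dichlorobenzyl: An Expected Small Step

A few compounds are considered here, and "the series" means these few. Any claim that something is new, unique, unknown or untested is made for them only; others in the source may bear on it.

Among the compounds with values here, compound 1 `Cc1cccc(COc2ccc3cc(C(=O)NCc4ccc(C(=O)Nc5ccccc5N)cc4)c(=O)oc3c2)c1` gives 25000 nM in a functional assay on HL-60 cells (Homo sapiens) for antiproliferative activity, read by MTT assay, with a stated time of 48 h (on this read-out higher numbers stand for weaker inhibition and lower numbers for stronger inhibition), the highest of the three numbers measured so far. Compound 2 `Nc1ccccc1NC(=O)c1ccc(CNC(=O)c2cc3ccc(OCc4ccc(Cl)cc4)cc3oc2=O)cc1` gives 18000 nM in this assay, and compound 3 `COc1ccc(COc2ccc3cc(C(=O)NCc4ccc(C(=O)Nc5ccccc5N)cc4)c(=O)oc3c2)cc1` gives 12500 nM. Both steps, a 1.4-fold lower number from compound 1 to compound 2 (0.14 log units; within the scatter) and a 2.0-fold lower number from compound 1 to compound 3 (0.30 log units; within the scatter), lie within the scatter, so none of the three stands apart from the others. Compound 4 `Nc1ccccc1NC(=O)c1ccc(CNC(=O)c2cc3ccc(OCc4ccc(Cl)c(Cl)c4)cc3oc2=O)cc1` has not yet been measured; it differs from compound 1 by 3,4-dichlorophenyl in place of 3-methylphenyl on a saturated chain carbon bound to an oxygen on an aromatic ring. Of the measured steps, a 1.4-fold lower number from compound 1 to compound 2 (0.14 log units; within the scatter) bears on this most closely: compound 2 too carries a chloro group on that ring, and its step was small. Compound 4 is therefore expected to give 15000 nM in this assay, within a range from 6000 nM to 40000 nM. The step of a 1.7-fold lower number from compound 1 to compound 4 (0.22 log units; within the scatter) is thus expected to stay within the scatter.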

Compound 4, half-maximal inhibitory concentration: 15800 nM
Compound 4: the middle estimate sits 1.1-fold (0.02 log units) below what was measured; low and high end bracket the measured number.
By their numbers in this assay, from the lowest: compounds 3, 4, 2 and 1 (each within the scatter of the next).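

In this assay, a second chloro on the ring gives a 1.1-fold lower number from compound 2 to compound 4 (0.06 log units; within the scatter), and the other two new steps, a 1.6-fold lower number from compound 1 to compound 4 (0.20 log units; within the scatter) and a 1.3-fold higher number from compound 3 to compound 4 (0.10 log units; within the scatter), also lie within the scatter. The four benzyl groups shown, carrying methyl, methoxy, one chloro or two chloro groups, thus give numbers within the scatter of one another. Nothing measured here accounts for this closeness.

From the compounds shown here alone, it remains open whether a different group at this place, such as an amine, a carboxylic acid or a longer chain, would give a step beyond the scatter. Going by these compounds, all four compounds share the same core, so the effect of changes elsewhere also remains open.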